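The source may hold more compounds than are shown below. What is called first, only, known or untested is meant among the compounds shown, and "the series" means these compounds.

Measured so far in a functional assay on LNCaP cells (Homo sapiens) for antiproliferative activity, read by WST assay, with a stated time of 3 days; a higher number here means a weaker inhibitor, a lower number a stronger inhibitor:
compound 1 `CCCCOc1c(-c2cc(OC)c(OC)c(OC)c2)oc2ccccc2c1=O` gives 8900 nM
compound 2 `CCCCN(CCCC)CCCCOc1c(-c2cc(OC)c(OC)c(OC)c2)oc2ccccc2c1=O` gives 7800 nM
compound 3 `CCCCN(CCCC)CCCCCOc1c(-c2cc(OC)c(OC)c(OC)c2)oc2ccccc2c1=O` gives 7800 nM

The three numbers sit close together. On the numbers shown, compound 1 stands at one edge of a narrow spread, and neither neighbour is separated from it by more than the scatter: a 1.1-fold lower number from compound 1 to compound 2 (0.06 log units; within the scatter) and a 1.1-fold lower number from compound 1 to compound 3 (0.06 log units; within the scatter). The two amine-bearing compounds also sit on top of each other, no change at the digits printed from compound 2 to compound 3 (within the scatter).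

Compound 4 `CCCCCN(CCCCC)CCCCCOc1c(-c2cc(OC)c(OC)c(OC)c2)oc2ccccc2c1=O` is the next compound on the same chain. Compared with compound 1 the change is (dipentylamino)methyl in place of hydrogen on a saturated chain carbon, four bonds along the chain from an oxygen on an aromatic ring.

Within the data shown here, the steps that bear on this are those from compound 1 to compound 2 and from compound 1 to compound 3, where a dibutylamino or a (dibutylamino)methyl group entered at the same place on the chain. Both were within the scatter. Compound 4 carries a somewhat longer amine-bearing group, but nothing in the three measurements suggests that lengthening the chain moves the number. The expectation for compound 4 in this assay is therefore a step of a 1.2-fold lower number from compound 1 to compound 4 (0.07 log units; within the scatter), that is, no step beyond the scatter. Compound 4 is estimated at 7500 nM, with a range from 3500 nM to 16000 nM.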

Compound 4, half-maximal inhibitory concentration: 7900 nM
The estimate for compound 4 lay 1.1-fold (0.02 log units) below the measured number; measured number inside the range.
By their numbers in this assay, from the lowest: compounds 2, 3, 4 and 1 (each within the scatter of the next).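

In this assay, (dipentylamino)methyl, with its 12 heavy atoms, on the saturated chain carbon four bonds along the chain from an oxygen on an aromatic ring gives a 1.1-fold lower number from compound 1 to compound 4 (0.05 log units; within the scatter), so a third and larger amine-bearing group at this position also produces no step beyond the scatter. The first change made only to the chains on the nitrogen, dipentylamino in place of dibutylamino, gives a 1.0-fold higher number from compound 3 to compound 4 (0.01 log units; within the scatter), and the wider change from dibutylamino to (dipentylamino)methyl gives a 1.0-fold higher number from compound 2 to compound 4 (0.01 log units; within the scatter), so neither change separates these amine-bearing compounds from one another. No supporting measurement is available to explain this flat result.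

The compounds shown leave open whether a much smaller amine such as dimethylamino, or a carboxylic acid, at the end of this chain would give a step beyond the scatter. They also leave open whether a much longer chain carrying the same dibutylamino group would keep the number in the same place.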